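Naphthalene in Place of Ethylphenyl on a Non-Cytotoxic Core

The source may report more compounds than this note shows. Statements on the series, on what has been measured and on what is new or still open speak of the compounds shown alone.

Compound 1 `CCc1ccc(-c2nc3c(c(C)nn3-c3ccccc3)c(-c3ccccc3O)c2C#N)cc1` was examined in an ADME assay on BJ cells (Homo sapiens) for cytotoxicity, with a stated time of 72 h; on this read-out higher numbers stand for an effect only at larger amounts of compound and lower numbers for an effect already at smaller amounts. In this assay compound 1 gives > 20000 nM, which is a limit of the assay rather than a number. Compound 2 `CCc1ccc(-c2nc3c(c(C)nn3-c3ccccc3)c(-c3ccccc3)c2C#N)cc1` likewise gives only a limit, > 20000 nM. Compound 3 `CCc1ccc(-c2nc3c(c(C)nn3-c3ccccc3)c(-c3ccccc3C(=O)OC)c2C#N)cc1` also gives only a limit, > 20000 nM. As a result the steps a step that the two limits leave unreadable from compound 1 to compound 2, a step that the two limits leave unreadable from compound 1 to compound 3 and a step that the two limits leave unreadable from compound 2 to compound 3 cannot be sized; all that is known is the limit of > 20000 nM in this assay, at which 3 of the 3 values shown sit. Compound 4 `Cc1nn(-c2ccccc2)c2nc(-c3ccc4ccccc4c3)c(C#N)c(-c3ccccc3O)c12` differs from compound 1 by naphthalen-2-yl in place of 4-ethylphenyl on an aromatic carbon. Within the data shown here, none of the measured steps concerns this position, so nothing points to a change beyond the scatter. Compound 4 is therefore expected to give 20000 nM, with a range from 10000 nM to 40000 nM. The step expected from this is a number no higher from compound 1 to compound 4 (the limit leaves the size open), most likely again reported as a limit.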

Compound 4, half-maximal effective concentration: > 20000 nM
Compound 4: no number, only a limit; the forecaster's own chance of this, stated with the estimate: 80%; the middle value lies on the limit itself.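

Compound 4, like compound 1, gives only a limit of the assay, so the step between them cannot be read. The compounds shown leave open at what amount any of them would show an effect in this assay.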